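This account rests on a few compounds, and the source may have more. Where it says the series, first, only, none or still open, it means among the compounds named here.

Three compounds have been measured in a functional assay on KB cells (Homo sapiens) for cytotoxicity, read by MTT assay, with a stated time of 72 h; a lower number here means a stronger inhibitor, a higher number a weaker inhibitor:

Compound 1, `O=C(NC(=S)NNc1ncnc2ccccc12)c1ccccc1F`, gives 2510 nM.
Compound 2, `COc1cc2ncnc(NNC(=S)NC(=O)c3ccccc3Cl)c2cc1OC`, gives 3560 nM.
Compound 3, `COc1cc2ncnc(NNC(=S)NC(=O)c3ccc(Cl)cc3)c2cc1OC`, gives 4590 nM.

Compound 3 stands at the highest of the three numbers, but its gap to compound 2 and its gap to compound 1 both lie within the usual scatter of repeated measurements, so on these data the three compounds cannot be told apart. Compound 4, `COc1cc2ncnc(NNC(=S)NC(=O)c3ccccc3)c2cc1OC`, has not yet been measured. It differs from compound 3 in one place: hydrogen in place of chloro on an aromatic carbon. Within the data shown here, only one measured step is of a related kind, the exchange of 2-chlorophenyl for 4-chlorophenyl, a 1.3-fold higher number from compound 2 to compound 3 (0.11 log units; within the scatter), which stayed within the scatter. Among the measured compounds shown here, no measured step removes a chloro group altogether, and compound 1 differs from the others in more than one place, so its value shows only that a compound with a different halogen and a different core also lands in the same region. The expectation for compound 4 is therefore a step of no size beyond the scatter, a 1.1-fold lower number from compound 3 to compound 4 (0.06 log units; within the scatter). Compound 4 is estimated at 4000 nM, within a range from 1800 nM to 9000 nM.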

Compound 4, half-maximal inhibitory concentration: 3770 nM
Estimate against measurement, compound 4: 1.1-fold (0.03 log units) above; low and high end bracket the measured number.
By their numbers in this assay, from the lowest: compounds 1, 2, 4 and 3 (each within the scatter of the next).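

Taking the chloro group off the 4-chlorophenyl of compound 3, which leaves a plain phenyl, gives a step in this assay that can be read directly (a 1.2-fold lower number from compound 3 to compound 4 (0.09 log units; within the scatter)), so the chlorine at this place on the ring, para to a large group, has no effect that can be told from the scatter. The same exchange of chloro for hydrogen, starting from the 2-chlorophenyl of compound 2, also stays small (a 1.1-fold higher number from compound 2 to compound 4 (0.02 log units; within the scatter)), which extends the earlier finding: moving the chlorine made no readable difference, and neither does removing it from either place. No independent measurement is available to explain this flat result, so it stands as an observation alone.

The compounds shown leave open whether a quite different group in place of the chloro, such as an amine, a carboxylic acid or a longer alkyl chain, would move the number beyond the scatter. Among these compounds, they also give no step that changes the core alone, since compound 1 differs from the others in more than one place, so what the two methoxy groups contribute cannot be read.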